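Replacing 3-fluorophenyl with methyl: notes on compound 4

The source may report more compounds than this note shows. Statements on the series, on what has been measured and on what is new or still open speak of the compounds shown alone.

In an ADME assay on L6 cells (Rattus norvegicus) for cytotoxicity, read by fluorescence and resazurin assay, with a stated time of 72 h (a lower number here means that less compound is needed, a higher number that more compound is needed for the effect), compound 2 `O=c1nc(-c2ccccc2)c2cc(-c3cccc(F)c3)ccc2[nH]1` gives 23000 nM, the lowest of the two actual numbers in the series. Compound 1 `O=c1nc(-c2ccccc2)c2cc(-c3ccccc3F)ccc2[nH]1` gives 55800 nM. Compound 3 `CNC(=O)c1cccc(-c2ccc3[nH]c(=O)nc(-c4ccccc4)c3c2)c1` is reported only as a limit, > 50000 nM.

Compound 4 `Cc1ccc2[nH]c(=O)nc(-c3ccccc3)c2c1` has methyl in place of 3-fluorophenyl on an aromatic carbon.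

Going by the values given here, two measured steps bear on this change, and both are modest: a 2.4-fold lower number from compound 1 to compound 2 (0.38 log units; beyond the scatter), and an at least 2.1-fold higher number from compound 2 to compound 3 (0.33 log units; beyond the scatter). Neither replaces the whole 3-fluorophenyl group, so they guide the size of the expected step only loosely. Among the compounds with values here, the direction rests on the single rise to compound 3, an at least 2.1-fold higher number from compound 2 to compound 3 (0.33 log units; beyond the scatter). Also relevant is the limit of > 50000 nM in this assay, at which 1 of the 3 values shown sits.

A modest rise is expected in this assay, a 2.2-fold higher number from compound 2 to compound 4 (0.34 log units; beyond the scatter).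

For compound 4 the estimated value is 50000 nM, with an expected range of 20000 nM to 120000 nM.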

Compound 4, half-maximal effective concentration: > 50000 nM
Compound 4 was reported as a limit; the forecaster's own chance of this, stated with the estimate: 50%; the middle value sits exactly at the limit.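

In this assay compound 4 gives > 50000 nM, which is a limit and not a number. Replacing 3-fluorophenyl with methyl gives an at least 2.1-fold higher number from compound 2 to compound 4 (0.33 log units; beyond the scatter), the first step shown that removes the aromatic ring from this position rather than changing a substituent on that ring. The step between compound 1 and compound 4 cannot be read, and the series now sits at the limit more often: the limit of > 50000 nM in this assay, at which 2 of the 4 values shown sit.

As far as these compounds go, how far compound 3 and compound 4 lie beyond the limit remains unknown, so these two cannot be ordered. Also open, from the compounds shown here alone, is whether an amine, a carboxylic acid or a longer chain in place of methyl would bring the number back towards that of compound 2 or leave it at the limit.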